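Ethoxy to Trifluoromethoxy on the Aryl Group of Compound 2

A few compounds are considered here, and "the series" means these few. Any claim that something is new, unique, unknown or untested is made for them only; others in the source may bear on it.

Among the measured compounds shown here, compound 2 `CCOc1ccc(-n2c(C)nc3c(NC(C4CC4)C4CC4)nc(C)nc32)cc1` gives 20 nM in a functional assay on CHO cells for antagonist activity at corticotropin-releasing factor receptor 1 (Homo sapiens), read by cAMP accumulation (a higher number here means a weaker inhibitor, a lower number a stronger inhibitor), the lowest of the two numbers known in this set. For the measured compounds named here, its only measured neighbour, compound 1 `Cc1nc(NC(C2CC2)C2CC2)c2nc(C)n(-c3ccc(S(C)(=O)=O)cc3)c2n1`, gives 140 nM in this assay. Going by the values given here, the one measured step, a 7.0-fold lower number from compound 1 to compound 2 (0.85 log units; beyond the scatter), came from ethoxy in place of methylsulfonyl on an aromatic carbon.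

Compound 3 `Cc1nc(NC(C2CC2)C2CC2)c2nc(C)n(-c3ccc(OC(F)(F)F)cc3)c2n1` differs from compound 2 by trifluoromethyl in place of ethyl on an oxygen on an aromatic ring. Among the compounds with values here, no measured step in this set bears on that exchange; the step from compound 1 to compound 2 concerns a different group at the same aromatic carbon, so it offers no direct guide. With the oxygen retained and only the group on it changed, compound 3 is expected to stay near compound 2, a step of a 1.5-fold higher number from compound 2 to compound 3 (0.18 log units; within the scatter) that is not expected to go beyond the scatter. Compound 3 is therefore estimated at 30 nM in this assay, within a range of 8 nM to 110 nM.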

Compound 3, inhibition constant: 9 nM
For compound 3 the middle estimate is 3.3-fold (0.52 log units) above the measured one; low and high end bracket the measured number.
By their numbers in this assay, from the lowest: compound 3; then compound 2; then compound 1.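

In this assay the group on the oxygen on the aromatic ring proves to matter even with the oxygen retained: trifluoromethyl in place of ethyl gives a 2.2-fold lower number from compound 2 to compound 3 (0.35 log units; beyond the scatter) and so moves the number beyond the scatter. Trifluoromethoxy in place of methylsulfonyl gives a 16-fold lower number from compound 1 to compound 3 (1.19 log units; beyond the scatter) as the largest step in this set, which places trifluoromethoxy, ethoxy and methylsulfonyl in that order, from the lowest number, at this aromatic carbon. No measured evidence here accounts for either step.

The compounds shown leave open whether a longer chain such as propoxy, or difluoromethoxy, would fall with trifluoromethoxy or with ethoxy, and how an amine or a carboxylic acid at the same aromatic carbon would compare. From the compounds shown here alone, all three compounds share the rest of the core, so whether this order holds with other groups there remains unknown.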